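Aryloxyacetamide in place of arylpropanamide on the piperazine amide

The source may report more compounds than this note shows. Statements on the series, on what has been measured and on what is new or still open speak of the compounds shown alone.

Compound 3 `COc1ccc(CC(C)C(=O)N2CCN(c3ccc(C(F)(F)F)cc3[C@@H](N)CC(C)C)CC2)cc1` gives the lowest number of the three measured in an assay on HEK293 cells for displacement of a labelled ligand from Melanocortin receptor 4 (Homo sapiens) (a higher number here means a weaker inhibitor, a lower number a stronger inhibitor), at 120 nM. Its nearest neighbour is compound 1 `COc1cc(CC(C)C(=O)N2CCN(c3ccc(C(F)(F)F)cc3[C@@H](N)CC(C)C)CC2)ccc1Cl`, which in this assay gives 230 nM, the two lying within the scatter; the furthest is compound 2 `Cc1ccc(OCC(=O)N2CCN(c3ccc(C(F)(F)F)cc3[C@@H](N)CC(C)C)CC2)cc1`, which in this assay gives 4400 nM.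

Compound 4 `CC(C)C[C@H](N)c1cc(C(F)(F)F)ccc1N1CCN(C(=O)COc2cccc3ccccc23)CC1` is still to be measured in this assay. It differs from compound 3 in one place: ((naphthalen-1-yl)oxy)methyl in place of 1-(4-methoxybenzyl)ethyl on a carbonyl carbon. The measured steps that bear on this are the two that swap a 1-(benzyl)ethyl group on the carbonyl carbon for an aryloxymethyl group. In one direction, a 19-fold higher number from compound 1 to compound 2 (1.28 log units; beyond the scatter); in the other, a 37-fold lower number from compound 2 to compound 3 (1.56 log units; beyond the scatter). Both steps are large and both point the same way: the aryloxymethyl amide gives the higher number. Nothing in the series shows how a two-ring aryl ether compares with a one-ring one, so the size of the naphthyl group adds uncertainty rather than direction.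

On this basis a large rise in the number is expected for compound 4, a 21-fold higher number from compound 3 to compound 4 (1.32 log units; beyond the scatter). The estimate for compound 4 in this assay is 2500 nM, with a range from 600 nM to 10000 nM.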

Compound 4, inhibition constant: 2600 nM
Compound 4: the middle estimate sits 1.0-fold (0.02 log units) below what was measured; the measured number falls inside the stated range.
By their numbers in this assay, from the lowest: compounds 3 and 1 (each within the scatter of the next); then compounds 4 and 2 (each within the scatter of the next).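

On the carbonyl carbon, ((naphthalen-1-yl)oxy)methyl repeats in this assay the pattern first seen with the one-ring aryl ether: the swap gives a 22-fold higher number from compound 3 to compound 4 (1.34 log units; beyond the scatter) against the 4-methoxy partner and an 11-fold higher number from compound 1 to compound 4 (1.05 log units; beyond the scatter) against the 4-chloro-3-methoxy partner. New here is the aryl part of the ether: naphthalen-1-yl in place of 4-methylphenyl on the oxygen gives a 1.7-fold lower number from compound 2 to compound 4 (0.23 log units; within the scatter) and so leaves the two ethers inseparable in this assay, even with the second aromatic ring added. Across these four compounds, the large gaps therefore follow the choice of aryloxymethyl or 1-(benzyl)ethyl on the carbonyl carbon, and no compound shown goes against this, while the two aryl groups on the ether oxygen make no difference beyond the scatter. No measurement shown gives a reason for the gap.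

Still open, from the compounds shown here alone, is which part of the aryloxymethyl group carries the difference, the ether oxygen or the absence of the methyl branch, and a plain 3-arylpropanoyl chain, or a nitrogen in place of the ether oxygen, would separate the two. Also open, going by these compounds, is how naphthalen-2-yl on the oxygen, or an aryl ether bearing a methoxy group or a chlorine, would compare.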